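A few compounds are considered here, and "the series" means these few. Any claim that something is new, unique, unknown or untested is made for them only; others in the source may bear on it.

In an ADME assay on a cell-free system (plasma, Homo sapiens) for metabolic stability (on this read-out higher numbers stand for a longer-lived compound and lower numbers for a shorter-lived compound), compound 1 `CC(=O)N1C(=O)C(C)(C)[C@@H]2[C@@H]1CCN2C(=O)OCc1ccccc1` gives 6.5 h as its half-life. Compound 2 `COC(=O)N1C(=O)[C@@H](C)[C@@H]2[C@@H]1CCN2C(=O)OCc1ccccc1` gives 0.833 h as its half-life. Compound 3 `C[C@@H]1C(=O)N(S(C)(=O)=O)[C@H]2CCN(C(=O)OCc3ccccc3)[C@H]12` gives < 0.0834 h as a limit of the assay and not a number. Compound 4 `CNC(=O)N1C(=O)[C@@H](C)[C@@H]2[C@@H]1CCN2C(=O)OCc1ccccc1` has methylcarbamoyl in place of methylsulfonyl on an amide-type nitrogen in a ring. The measured step that bears on this is an at least 9.9-fold lower number from compound 2 to compound 3 (0.99 log units; beyond the scatter) for methylsulfonyl in place of methoxycarbonyl on that nitrogen. Methylcarbamoyl, like the methoxycarbonyl of compound 2 at 0.833 h on this read-out, puts a carbonyl back there, so a rise of comparable size is expected in this assay rather than a step within the scatter. The expected change is an at least 9.5-fold higher number from compound 3 to compound 4 (0.98 log units; beyond the scatter) on this estimate. For compound 4 the estimate is 0.8 h (expected range 0.15 h to 4 h).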

Compound 4, half-life: > 24 h
Compound 4 gave a limit, no number; the forecaster's own chance of this, stated with the estimate: 10%; middle value at least 30-fold (1.47 log units) from the limit.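

In this assay compound 4 gives > 24 h as a limit of the assay and not a number. The result gives an at least 280-fold higher number from compound 3 to compound 4 (2.45 log units; beyond the scatter) for methylcarbamoyl in place of methylsulfonyl on the amide-type nitrogen in a ring, and an at least 28-fold higher number from compound 2 to compound 4 (1.45 log units; beyond the scatter) for methylamino in place of methoxy on a carbonyl carbon. Compound 2 and compound 4 both carry a carbonyl there, so a carbonyl alone does not set the half-life at this position.

Where dimethylcarbamoyl or ethylcarbamoyl would fall on this read-out remains open. Going by these compounds, the full size of both steps also remains open, because compound 4 stands at a limit: the limit of > 24 h in this assay, at which 1 of the 4 values shown sits.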